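The source may hold more compounds than are shown below. What is called first, only, known or untested is meant among the compounds shown, and "the series" means these compounds.

Measured in a functional assay on HCT-15 cells (Homo sapiens) for cytotoxicity, read by CCK-8 assay and cell counting, with a stated time of 2 days; a higher number here means a weaker inhibitor, a lower number a stronger inhibitor:
- compound 1 `Oc1ccc(-c2cc(-c3ccc(Cl)cc3)nc(-c3cccnc3)c2)cc1`: 20700 nM
- compound 2 `Oc1cccc(-c2cc(-c3ccc(Cl)cc3)nc(-c3cccnc3)c2)c1`: 16800 nM
- compound 3 `Oc1ccc(-c2cc(-c3cccnc3)nc(-c3cccc(Cl)c3)c2)cc1`: 21300 nM

Compound 1 sits inside a tight group of three numbers and is not separated from either of the others: a 1.2-fold lower number from compound 1 to compound 2 (0.09 log units; within the scatter) and a 1.0-fold higher number from compound 1 to compound 3 (0.01 log units; within the scatter). Next in the series is compound 4 `Oc1ccc(-c2cc(-c3ccc(Cl)cc3)nc(-c3ccccn3)c2)cc1`, which keeps the 4-hydroxyphenyl and 4-chlorophenyl groups of compound 1 and has pyridin-2-yl in place of pyridin-3-yl on an aromatic carbon.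

Among the compounds with values here, no measured step changes the pyridine attachment, so the evidence is indirect. The step to compound 2 replaces 4-hydroxyphenyl with 3-hydroxyphenyl, and the step to compound 3 replaces 4-chlorophenyl with 3-chlorophenyl. Both are small, as a 1.2-fold lower number from compound 1 to compound 2 (0.09 log units; within the scatter) and a 1.0-fold higher number from compound 1 to compound 3 (0.01 log units; within the scatter) show, and both stay within the scatter. On that basis, no change beyond the scatter is expected in this assay, and no direction can be argued with any confidence. Within the data shown here, the series offers no direct precedent for this change, so the range is kept wide. The expected result is a 1.2-fold lower number from compound 1 to compound 4 (0.06 log units; within the scatter), which would lie within the scatter. For compound 4 the estimated value is 18000 nM, with an expected range of 7000 nM to 40000 nM.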

Compound 4, half-maximal inhibitory concentration: 21300 nM
Compound 4: the middle estimate sits 1.2-fold (0.07 log units) below what was measured; the range from low to high includes it.
By their numbers in this assay, from the lowest: compounds 2, 1, 3 and 4 (each within the scatter of the next).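

In this assay, the pyridine now has a direct reading: pyridin-2-yl in place of pyridin-3-yl, which puts the attachment carbon next to the ring nitrogen, gives a 1.0-fold higher number from compound 1 to compound 4 (0.01 log units; within the scatter). Within the data shown here, the earlier steps covered only the hydroxyphenyl and chlorophenyl groups, so this is the first sign that moving the ring nitrogen in this group, with the same atoms joined differently, does not separate two compounds in this assay. With this step, a single rearrangement at each of the three aryl groups of compound 1 has been read, and none goes beyond the scatter. No measurement shown bears on the reason for this result.

All four compounds shown carry the same atoms, so it remains open whether a real change of group would move the number beyond the scatter, such as pyridin-4-yl or a plain phenyl at this position, a carboxylic acid or a methoxy group in place of the hydroxyl, or an amine in place of the chlorine. Among these compounds, also open is whether two of these rearrangements combined in one compound would stay as close as the single steps do.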